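The source may report more compounds than this note shows. Statements on the series, on what has been measured and on what is new or still open speak of the compounds shown alone.

The measured compounds in a functional assay on SF-295 cells (Homo sapiens) for cytotoxicity, read by sulforhodamine B assay, with a stated time of 48 h; on this read-out higher numbers stand for weaker inhibition of growth and lower numbers for stronger inhibition of growth:
compound 1, `ClCc1ccccc1Cn1cnc2c(Cl)nc(Cl)nc21`: 1900 nM
compound 2, `ClCc1ccccc1Cn1cnc2c(Cl)ncnc21`: 10500 nM
compound 3, `ClCc1cccc(Cn2cnc3c(Cl)ncnc32)c1`: 3230 nM

Compound 2 and compound 3 are built from the same atoms joined differently; the difference between their two cores is not broken down here, and their values show compound 3 at the lower number of the two in this assay. Compound 1 differs from compound 2 by a single change, (chloro in place of hydrogen on an aromatic carbon), and that change brought a 5.5-fold lower number from compound 2 to compound 1 (0.74 log units; beyond the scatter). Compound 4, `ClCc1cccc(Cn2cnc3c(Cl)nc(Cl)nc32)c1`, has not yet been measured; it carries the change chloro in place of hydrogen on an aromatic carbon relative to compound 3, the same change in the same surroundings, since the description of the place matches word for word in both cases. Because the earlier step of a 5.5-fold lower number from compound 2 to compound 1 (0.74 log units; beyond the scatter) was modest and beyond the scatter, a step of the same direction and similar size is expected here, namely a 4.6-fold lower number from compound 3 to compound 4 (0.66 log units; beyond the scatter). On that basis compound 4 is expected to give about 700 nM in this assay, with a plausible range from 250 nM to 2000 nM.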

Compound 4, concentration for 50% growth inhibition: 4360 nM
For compound 4 the middle estimate is 6.2-fold (0.79 log units) below the measured one; the whole stated range lies below it.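

In this assay, chloro in place of hydrogen on an aromatic carbon gave a 1.3-fold higher number from compound 3 to compound 4 (0.13 log units; within the scatter), so on this core the change brought no shift that stands out from the scatter. Set beside the earlier case, the same change did not carry over from one core to the other, even though the two cores are built from the same atoms joined differently: the same change on two cores in this assay, a 5.5-fold lower number (0.74 log units; beyond the scatter) from compound 2 to compound 1 and a 1.3-fold higher number (0.13 log units; within the scatter) from compound 3 to compound 4, 7.5-fold (0.87 log units) apart, beyond the scatter of two such steps. These two pairs give no reason for the gap, and they say nothing about how the change would behave on any further core.

Every compound shown has either hydrogen or chloro at this place, so it remains open whether another group there, such as an amine or a methoxy group, would depend on the core in the same way. All four compounds also keep the chloromethyl group, which leaves open what a hydroxymethyl group or a longer chain in its stead would do to the growth-inhibition numbers.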